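Fluoro for chloro on the styryl ring: a second test

A few compounds are considered here, and "the series" means these few. Any claim that something is new, unique, unknown or untested is made for them only; others in the source may bear on it.

Measured compounds in a functional assay on U-251 cells (Homo sapiens); on this read-out higher numbers stand for weaker inhibition of growth and lower numbers for stronger inhibition of growth:
compound 1 `O=S(=O)(/C=C/c1ccc(F)cc1)Cc1ccc(Nc2ncnc3ccccc23)cc1` gives 10 nM;
compound 2 `O=S(=O)(/C=C/c1ccc(Cl)cc1)Cc1ccc(Nc2ncnc3ccccc23)cc1` gives 49000 nM;
compound 3 `O=S(=O)(/C=C/c1ccc(F)cc1Cl)Cc1ccc(Nc2ncnc3cc(Cl)ccc23)cc1` gives 2000 nM.

All three share a sulfone that links an ethenyl-aryl arm to a benzylic aryl amine on a quinazoline-type core. Compound 1 and compound 2 differ in one spot only, and the change is fluoro in place of chloro on an aromatic carbon. That single swap made the step of a 4900-fold lower number from compound 2 to compound 1 (3.69 log units; beyond the scatter), so compound 1 is the strongest growth inhibitor of the three, and compound 2 the weakest.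

Compound 3 carries a chloro on its core and two halogens on the styryl ring; how its core differs from that of compound 2 is not broken down here. Its number stands between those of compound 1 and compound 2.

Compound 4 `O=S(=O)(/C=C/c1ccc(F)cc1F)Cc1ccc(Nc2ncnc3cc(Cl)ccc23)cc1` has not yet been tested. It differs from compound 3 by fluoro in place of chloro on an aromatic carbon. This is the same kind of change as from compound 2 to compound 1, but at a different place: there the swapped atom was para to a large group, here it is ortho to a large group and meta to a fluoro group. Because the earlier swap gave a 4900-fold lower number from compound 2 to compound 1 (3.69 log units; beyond the scatter), a lower number is expected for compound 4, though a smaller step seems the safer estimate given the changed surroundings. The expected step is a 13-fold lower number from compound 3 to compound 4 (1.12 log units; beyond the scatter). Compound 4 is estimated at 150 nM, with a likely range from 10 nM to 2000 nM.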

Compound 4, concentration for 50% growth inhibition: > 100000 nM
Compound 4 gave a limit, no number; the forecaster's own chance of this, stated with the estimate: 5%; middle value at least 660-fold (2.82 log units) away from the limit.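

In this assay compound 4 gives > 100000 nM, which is a limit of the assay and not a number. Even so, the swap of chloro for fluoro gives an at least 50-fold higher number from compound 3 to compound 4 (1.69 log units; beyond the scatter), the opposite direction from the earlier pair, so in these two pairs the change does not carry over from one core to the other as a reliable gain: the same change on two cores in this assay, a 4900-fold lower number (3.69 log units; beyond the scatter) from compound 2 to compound 1 and an at least 50-fold higher number (1.69 log units; beyond the scatter) from compound 3 to compound 4, at least 240000-fold (5.38 log units) apart, beyond the scatter of two such steps

This does not show that the swap always weakens growth inhibition on the chlorinated core, and it does not explain the reversal, since only two pairs are shown and they differ in their core, in where the swap sits on the styryl ring and in the other halogen on that ring. On these data alone, the true size of the new step also stays unknown, as one end of it is a limit.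

The compounds shown include no pair with the same styryl ring on both cores, so what the chloro on the core contributes by itself remains open. As far as these compounds go, it also remains open how this assay would respond to a methyl or a methoxy group in place of the halogen that was swapped.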